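Bromo to trifluoromethoxy on the dicyano-type aryl ring

This account rests on a few compounds, and the source may have more. Where it says the series, first, only, none or still open, it means among the compounds named here.

Going by the values given here, compound 3 `Cc1ccc2ccc(-c3cc(Br)cc(C#N)c3)cc2n1` gives 13 nM in a functional assay on CHO cells for inhibition of metabotropic glutamate receptor 5 (Rattus norvegicus), read by FLIPR and calcium flux (a higher number here means a weaker inhibitor, a lower number a stronger inhibitor), and holds the highest number of the three measured members. Compound 1 `Cc1ccc2ccc(-c3cc(C#N)cc(C#N)c3)cc2n1` gives 2 nM in this assay, and compound 2 `COc1cc(C#N)cc(-c2ccc3ccc(C)nc3c2)c1` gives 2.4 nM. The steps onto compound 3 are modest but beyond the scatter: a 6.5-fold higher number from compound 1 to compound 3 (0.81 log units; beyond the scatter) and a 5.4-fold higher number from compound 2 to compound 3 (0.73 log units; beyond the scatter), whereas a 1.2-fold higher number from compound 1 to compound 2 (0.08 log units; within the scatter). Compound 4 `Cc1ccc2ccc(-c3cc(C#N)cc(OC(F)(F)F)c3)cc2n1` differs from compound 3 by trifluoromethoxy in place of bromo on an aromatic carbon. Trifluoromethoxy, like methoxy, is attached through oxygen, so the methoxy-to-bromo step is the nearest guide, read in reverse. A lower number is therefore expected for compound 4, with an estimated step of a 2.6-fold lower number from compound 3 to compound 4 (0.41 log units; beyond the scatter), though reaching the methoxy level is uncertain. Compound 4 is expected to give 5 nM in this assay, within a range of 2 nM to 13 nM.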

Compound 4, half-maximal inhibitory concentration: 75 nM
Compound 4: the middle estimate sits 15-fold (1.18 log units) below what was measured, outside the stated range (above it).
By their numbers in this assay, from the lowest: compounds 1 and 2 (each within the scatter of the next); then compound 3; then compound 4.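

In this assay, trifluoromethoxy stands apart from the other three groups at this position: a 5.8-fold higher number from compound 3 to compound 4 (0.76 log units; beyond the scatter) is joined by larger steps, a 31-fold higher number from compound 2 to compound 4 (1.49 log units; beyond the scatter) and a 38-fold higher number from compound 1 to compound 4 (1.57 log units; beyond the scatter), all beyond the scatter. Attachment through oxygen does not by itself hold the number low here, since trifluoromethyl in place of methyl on that oxygen gives the second of these steps. No measurement shown accounts for this change. Still open, going by these compounds, is how an ethoxy, a chlorine or an amine at this position would compare with these four groups.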